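Exchanging the side ring on compound 3

The source may report more compounds than this note shows. Statements on the series, on what has been measured and on what is new or still open speak of the compounds shown alone.

In an ADME assay on CEM-SS cells (Homo sapiens) for cytotoxicity, read by XTT assay (on this read-out higher numbers stand for lower toxicity in this test and lower numbers for higher toxicity in this test), compound 1 `CN(O)C(=O)c1cc2ccn(Cc3ccc(F)cc3)c2cn1` gives 135000 nM and compound 2 `CN(O)C(=O)c1cc2ccn(Cc3ccc(F)cc3F)c2cn1` gives 200000 nM, which is a 1.5-fold higher number from compound 1 to compound 2 (0.17 log units; within the scatter). Compound 3 `CN(O)C(=O)c1cc2c(CN3CCC(O)C3)cn(Cc3ccc(F)cc3)c2cn1` reads > 100000 nM in this assay, which is a limit and not a number. Compound 4 `CN(O)C(=O)c1cc2c(CN3CCNC(=O)C3)cn(Cc3ccc(F)cc3)c2cn1` carries 3-oxopiperazin-1-yl in place of 3-hydroxypyrrolidin-1-yl on a saturated chain carbon bound to an aromatic carbon. Among the measured compounds shown here, no measured step covers this exchange. The closest is the one that added the side chain, a step that the limit leaves unreadable from compound 1 to compound 3, so it offers no size to carry over. The expected result is therefore no change beyond the scatter, an estimated step that the limit leaves unreadable from compound 3 to compound 4. Compound 4 is expected at 130000 nM, with an estimated range of 60000 nM to 280000 nM.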

Compound 4, half-maximal cytotoxic concentration: > 100000 nM
Compound 4 ended at the assay's limit; the forecaster's own chance of this, stated with the estimate: 60%; the middle value lies beyond the limit too.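

No new step can be read for compound 4, since compound 3 and compound 4 both stop at a limit and give no number: the limit of > 100000 nM in this assay, at which 2 of the 4 values shown sit.

The compounds shown leave open whether the 3-hydroxypyrrolidin-1-yl and 3-oxopiperazin-1-yl side chains differ at all in this read-out.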